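A few compounds are considered here, and "the series" means these few. Any claim that something is new, unique, unknown or untested is made for them only; others in the source may bear on it.

Measured so far:
- compound 1 `CCN(Cc1cccs1)C(=O)COc1ccc(F)cc1`: 422 nM
- compound 2 `Cc1ccc(OCC(=O)N(Cc2cccs2)c2nccs2)cc1`: 2240 nM
- compound 3 `CCN(Cc1cncs1)C(=O)COc1ccc(C)cc1`: 1100 nM

All three numbers come from an assay on HEK293 cells for agonist activity at transient receptor potential cation channel subfamily M member 8 (Homo sapiens), read by fluorescence and calcium flux, with a stated time of 15 min; a lower number here means that less compound is needed, a higher number that more compound is needed for the effect. Compound 1 has the lowest number of the three. The nearest is compound 3, whose higher number lies beyond the scatter of repeated measurements, and the furthest is compound 2, also beyond the scatter. Compound 4 `CCN(Cc1cccs1)C(=O)COc1ccc(C(F)(F)F)cc1` has not yet been measured. It differs from compound 1 in one place: trifluoromethyl in place of fluoro on an aromatic carbon. Among the compounds with values here, no measured pair shows this same change, so the size of its step is open. A step from compound 1 to compound 4 of about a 1.2-fold higher number from compound 1 to compound 4 (0.07 log units; within the scatter) is expected, that is, no clear change beyond the scatter in either direction. Compound 4 is estimated at 500 nM, with a range from 150 nM to 1800 nM.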

Compound 4, half-maximal effective concentration: 236 nM
Compound 4: middle estimate off by 2.1-fold (0.33 log units), on the high side; measured number inside the range.
By their numbers in this assay, from the lowest: compounds 4 and 1 (each within the scatter of the next); then compound 3; then compound 2.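

At this position, on an aromatic carbon para to a large group, trifluoromethyl can replace fluoro without a clear shift: in this assay the step is a 1.8-fold lower number from compound 1 to compound 4 (0.25 log units; within the scatter) and so stays within the scatter. Going from one heavy atom to four here therefore leaves the number where it was. No measured evidence bears on the reason for this result.

From the compounds shown here alone, whether an amine, a carboxylic acid or a longer chain would be accepted at this position remains open. So does whether the same change would behave alike on another core.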